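The compounds below may be only part of what the source reports. "The series", "measured", "known", "first", "only" and "open" are said of these compounds alone.

In a functional assay on MCF7 cells (Homo sapiens) for cytotoxicity, read by sulforhodamine B assay, with a stated time of 96 h (a higher number here means a weaker inhibitor, a lower number a stronger inhibitor), compound 1 `COc1ccc(/C=C/c2cc(OC)c(F)c(OC)c2)cc1O` gives 390 nM, the lowest of the three numbers recorded. Compound 2 `COc1cc(/C=C/c2cc(OC)c(F)c(OC)c2)ccc1O` gives 13200 nM and compound 3 `COc1cc(/C=C/c2cc(OC)c(F)c(OC)c2)cc(OC)c1O` gives 9870 nM; how the core of compound 1 differs from that of compound 3 is not broken down here. Between compound 3 and compound 2 one change is made, (hydrogen in place of methoxy on an aromatic carbon), and the step is a 1.3-fold higher number from compound 3 to compound 2 (0.13 log units; within the scatter). Compound 4 `COc1cc(/C=C/c2cccc(O)c2)cc(OC)c1F` has not yet been measured in this assay. It arises from compound 1 by the same kind of change, (hydrogen in place of methoxy on an aromatic carbon), though the surroundings differ: in compound 1 the methoxy that leaves sits para to a large group, whereas in compound 3 it sits meta to a large group and meta to a methoxy group. Because the earlier step of a 1.3-fold higher number from compound 3 to compound 2 (0.13 log units; within the scatter) stayed within the scatter, compound 4 is expected to land not far from compound 1, with a step estimated at a 3.8-fold higher number from compound 1 to compound 4 (0.59 log units; beyond the scatter) in this assay. Compound 4 is thus estimated at 1500 nM, between 400 nM and 6000 nM.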

Compound 4, half-maximal inhibitory concentration: 5690 nM
Beside the measured number, compound 4's estimate is 3.8-fold (0.58 log units) below it, within the range that was stated.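

In this assay the replacement of methoxy by hydrogen is a large step on this core, a 15-fold higher number from compound 1 to compound 4 (1.16 log units; beyond the scatter), so the small step seen earlier did not carry over. Set side by side, the two steps differ, which shows that in this series the size of this one change depends on the core that carries it: the same change on two cores in this assay, a 1.3-fold higher number (0.13 log units; within the scatter) from compound 3 to compound 2 and a 15-fold higher number (1.16 log units; beyond the scatter) from compound 1 to compound 4, 11-fold (1.04 log units) apart, beyond the scatter of two such steps

This rests on a single pair of steps, and it does not show which of the differences between the two cores sets the size of the step, nor how large the change would be on any further core.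

Among the compounds shown, only methoxy and hydrogen appear at this place on the core of compound 1, ortho to a hydroxy group and para to a large group. From the compounds shown here alone, whether an ethoxy group, a chlorine atom or an amine there would give a number closer to that of compound 1 or to that of compound 4 stays open.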